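Chloro to ethyl on the compound 1 scaffold

This account rests on a few compounds, and the source may have more. Where it says the series, first, only, none or still open, it means among the compounds named here.

Measured in a functional assay on A549 cells (Homo sapiens) for cytotoxicity, read by MTT assay, with a stated time of 72 h; a lower number here means a stronger inhibitor, a higher number a weaker inhibitor:
- Compound 1 `CNC(=O)c1cc(Oc2ccc(NC(=O)c3cc(-c4ccc(Cl)cc4)ncn3)cc2F)ccn1` gives > 100000 nM as a limit
- Compound 2 `CNC(=O)c1cc(Oc2ccc(NC(=O)c3nccc(-c4ccccc4)n3)cc2)ccn1` gives 26200 nM as a number
- Compound 3 `CNC(=O)c1cc(Oc2ccc(NC(=O)c3cc(-c4ccc(Cl)cc4)ncn3)cc2)ccn1` gives > 100000 nM as a limit

In this assay compound 1 stands at > 100000 nM as a limit and not a number. Its reading is the limit of > 100000 nM in this assay, at which 2 of the 3 values shown sit, and nothing more exact is known of it. Compound 4 `CCc1ccc(-c2cc(C(=O)Nc3ccc(Oc4ccnc(C(=O)NC)c4)c(F)c3)ncn2)cc1` comes from compound 1 by a single change ethyl in place of chloro on an aromatic carbon that puts ethyl in place of chloro on an aromatic carbon, para to a large group.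

Within the data shown here, the one measured step from compound 1 is a step that the two limits leave unreadable from compound 1 to compound 3 and it concerns hydrogen in place of fluoro, a different change. Compound 2 differs from compound 1 in more than one place. Among the measured compounds shown here, no measured step therefore gives a size for replacing chloro with ethyl, and no shift beyond the scatter is expected in this assay in either direction. Another limit reading is the likeliest outcome. The expected change is a number no higher from compound 1 to compound 4 (the limit leaves the size open) as an estimate only. For compound 4 the estimated value is 100000 nM with an expected range from 30000 nM to 300000 nM.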

Compound 4, half-maximal inhibitory concentration: 3390 nM
Compound 4: middle estimate off by 29-fold (1.47 log units), on the high side; measured number outside the range, below it.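

In this assay, putting ethyl in place of chloro gives an at least 29-fold lower number from compound 1 to compound 4 (1.46 log units; beyond the scatter), so the reading of the core of compound 1 does respond to the group at this place on the aromatic ring. That size is only a minimum, because compound 1 stands at a limit and not a number: the limit of > 100000 nM in this assay, at which 2 of the 4 values shown sit. The one earlier step, hydrogen in place of fluoro, cannot be read, which leaves this as the only single change shown with a readable size.

On these data alone, how a methyl group, a longer chain such as propyl, or an amine would read at this place stays open. As far as these compounds go, it is also open whether ethyl in place of chloro would give a similar step on compound 3, which carries hydrogen instead of the fluoro.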